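Thiosemicarbazide series: chlorophenyl to fluorophenyl at the carbonyl

This account rests on a few compounds, and the source may have more. Where it says the series, first, only, none or still open, it means among the compounds named here.

Two compounds of the series have been run in a functional assay on MCF7 cells (Homo sapiens) for cytotoxicity, read by MTT assay, with a stated time of 72 h; on this read-out higher numbers stand for weaker inhibition and lower numbers for stronger inhibition. Compound 1 `COc1cc2ncnc(NNC(=S)NC(=O)c3ccccc3C)c2cc1OC` carries two methoxy groups on its core and gives 19300 nM. Compound 2 `O=C(NC(=S)NNc1ncnc2ccccc12)c1cccc(Cl)c1` has the bare core and a 3-chlorophenyl group on the carbonyl carbon; in this assay compound 2 gives 3540 nM, the lower of the two numbers, and the gap to compound 1 lies beyond the scatter of repeated measurements.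

Compound 3 `O=C(NC(=S)NNc1ncnc2ccccc12)c1ccccc1F` is the next member, not yet measured. It differs from compound 2 as follows: 2-fluorophenyl in place of 3-chlorophenyl on a carbonyl carbon. Within the data shown here, nothing so far shows how such a change in the aryl group plays out, so the direction of the step is open; a step of moderate size is expected, and a weakening is taken as slightly more likely than a strengthening. For compound 3 the estimate is 6000 nM, with a range from 2000 nM to 18000 nM, which means an expected step of a 1.7-fold higher number from compound 2 to compound 3 (0.23 log units; within the scatter).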

Compound 3, half-maximal inhibitory concentration: 5020 nM
Compound 3: the middle estimate sits 1.2-fold (0.08 log units) above what was measured, and the stated range covers the measured number.
By their numbers in this assay, from the lowest: compounds 2 and 3 (each within the scatter of the next); then compound 1.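

In this assay, 2-fluorophenyl in place of 3-chlorophenyl on a carbonyl carbon gives a 1.4-fold higher number from compound 2 to compound 3 (0.15 log units; within the scatter) and so the two aryl groups cannot be told apart at this position on this read-out. Among these compounds, this is the first reading of a change at this position, and it covers the halogen and its numbered place on the phenyl ring together, so neither part can be judged alone. No measurement here bears on a cause for this outcome.

Still open, as far as these compounds go, is whether an unsubstituted phenyl group, or a phenyl ring carrying an amine or a carboxylic acid, would give a number beyond the scatter from compound 2. Compound 1 differs from compound 2 in more than one place, so the contribution of the two methoxy groups on its core cannot be read.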